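The source may report more compounds than this note shows. Statements on the series, on what has been measured and on what is new or still open speak of the compounds shown alone.

Of the compounds shown here, three of one series have been measured in a functional assay on the whole organism (strain Wistar) for inhibition, with Rattus norvegicus as the target, read by paw edema, with stated times of 60 min and 2 h, at a dose of 100 mg/kg by the oral route; a higher number here means more inhibition at the dose given (going by the name of the read-out), a lower number less inhibition. Compound 1 `COc1cc2c(cc1OC)C(CC(=O)NC(C)(C)C)CC2` gives 32%. Compound 2 `COc1cc2c(cc1OC)C(CC(=O)NC1CCCCC1)CC2` gives 56%, and compound 3 `COc1cc2c(cc1OC)C(CC(=O)NCc1ccccc1)CC2` gives 24%. Compound 3 stands lowest of the three numbers; its nearest neighbour is compound 1, with the step of a number 8 percentage points lower from compound 1 to compound 3 (within the scatter) lying within the scatter, whereas a number 32 percentage points lower from compound 2 to compound 3 (beyond the scatter) lies beyond it. Among the measured compounds shown here, the only change so far that moved the number upward beyond the scatter is a number 24 percentage points higher from compound 1 to compound 2 (beyond the scatter).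

Compound 4 `COc1cc2c(cc1OC)C(CC(=O)NCCO)CC2` has not yet been measured. It differs from compound 3 in one place: hydroxymethyl in place of phenyl on a saturated chain carbon bound to an amide-type nitrogen. For the measured compounds named here, no measured step exchanges a ring for a hydroxymethyl group, so the earlier steps at the amide-type nitrogen bear on it only in a general way: replacing the amide substituent has given one step within the scatter and one large step, and the change here removes a ring rather than exchanging one for another. On that basis no step beyond the scatter is expected in this assay for compound 4, and the estimated step is a number 1 percentage points higher from compound 3 to compound 4 (within the scatter). Compound 4 is accordingly expected to give about 25%, with an estimated range from 10% to 42%.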

Compound 4, a percentage reported as inhibition, in the whole organism at one dose (the size of the read-out at that dose, not a potency): 0%
The estimate for compound 4 lay 25 percentage points above the measured number; measured number outside the range, below it.
By their numbers in this assay, from the lowest: compound 4; then compounds 3 and 1 (each within the scatter of the next); then compound 2.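

In this assay, the step of a number 24 percentage points lower from compound 3 to compound 4 (beyond the scatter) shows that the group on the saturated chain carbon bound to the amide-type nitrogen can matter beyond the scatter, even though benzyl and tert-butyl could not be told apart by the earlier step of a number 8 percentage points lower from compound 1 to compound 3 (within the scatter). Among the compounds shown here, until now, the only step down beyond the scatter was the exchange of cyclohexyl for benzyl, and 2-hydroxyethyl now gives two further ones: a number 32 percentage points lower from compound 1 to compound 4 (beyond the scatter) and a number 56 percentage points lower from compound 2 to compound 4 (beyond the scatter). The 2-hydroxyethyl group therefore stands beyond the scatter below all three other amide substituents shown, and it is the only one of the four that carries oxygen, so this position has now been seen to give both the highest and the lowest numbers of the set.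

No measurement to hand explains this step. The compounds shown leave open whether the step follows from the hydroxyl itself or from the loss of the phenyl ring, a question that a plain ethyl, a 2-methoxyethyl, a longer chain ending in a hydroxyl, or a chain ending in an amine on the same nitrogen would bear on.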